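The source may hold more compounds than are shown below. What is called first, only, known or untested is meant among the compounds shown, and "the series" means these compounds.

Measured so far:
Compound 1 `COc1ccccc1N1CCN(CCCCc2cn(-c3ccccc3)nn2)CC1`: 486 nM
Compound 2 `OC(CCn1cc(-c2ccc(-c3ccccc3)cc2)nn1)CN1CCN(c2cccc(Cl)c2Cl)CC1`: > 7000 nM, a limit of the assay, not a number

Both were tested in an assay on HEK293 cells for displacement of a labelled ligand from D(4) dopamine receptor (Homo sapiens), read by scintillation counting, with a stated time of 1 h; a higher number here means a weaker inhibitor, a lower number a stronger inhibitor. Compound 1 gives a measured number, 486 nM. For compound 2 only a limit came back, > 7000 nM, which is the assay's own boundary rather than a value (the limit of > 7000 nM in this assay, at which 1 of the 2 values shown sits). Compound 2 therefore stands at the weak end of what this assay can resolve, and how far beyond that boundary it lies is not known.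

Compound 3 `OC(CCn1cc(-c2ccc3ccccc3c2)nn1)CN1CCN(c2cccc(Cl)c2Cl)CC1` has not yet been measured. It differs from compound 2 in one place: naphthalen-2-yl in place of 4-phenylphenyl on an aromatic carbon. Among the compounds with values here, no pair of measured compounds here differs in a single place, so there is no measured step to lean on. Since compound 2 is known only as a limit, the direction of the change can only be guessed; a modest gain, with wide uncertainty, is expected as an at least 1.7-fold lower number from compound 2 to compound 3 (0.24 log units; that floor lies within the scatter). Compound 3 is expected to give about 4000 nM, somewhere between 800 nM and 20000 nM.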

Compound 3, inhibition constant: > 20000 nM
Compound 3 was reported as a limit (the forecaster's own chance of this, stated with the estimate: 45%); middle value at least 5.0-fold (0.69 log units) from the limit.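

In this assay, compound 2 and compound 3 are each known only as a limit, not a number, so the step between them cannot be read. Left open is whether naphthalen-2-yl or 4-phenylphenyl gives the stronger inhibitor on the shared core.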